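Chloromethylbenzyl purines: removing one chloro from compound 1

The source may report more compounds than this note shows. Statements on the series, on what has been measured and on what is new or still open speak of the compounds shown alone.

Compound 1 `ClCc1cccc(Cn2cnc3c(Cl)nc(Cl)nc32)c1` is the reference point of this small set, tested in a functional assay on ACHN cells (Homo sapiens) for cytotoxicity, read by sulforhodamine B assay, with a stated time of 48 h (on this read-out lower numbers stand for higher toxicity in this test and higher numbers for lower toxicity in this test), where compound 1 gives 7240 nM. On the three numbers available this is the lowest, but the gap to compound 3 `ClCc1cccc(Cn2cnc3ncnc(Cl)c32)c1` is within the scatter: in this assay compound 3 gives 7760 nM, so the two cannot be ordered. Compound 2 `Nc1nc(Cl)c2ncn(Cc3ccccc3CCl)c2n1` stands clearly apart; in this assay compound 2 gives 75900 nM, a number beyond the scatter from compound 1. Compound 2 differs from compound 1 in more than one place, so nothing beyond the two values themselves can be read from that pair.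

Compound 4 `ClCc1cccc(Cn2cnc3c(Cl)ncnc32)c1` has not yet been tested. Relative to compound 1 the change is hydrogen in place of chloro on an aromatic carbon, leaving only the chloro meta to the site of removal in place. Going by the values given here, no single-point step between measured compounds exists to calibrate this change, so the expected size of a 1.7-fold higher number from compound 1 to compound 4 (0.22 log units; within the scatter) rests on the fact that compound 3, which also carries a single chloro on the core, sits within the scatter of compound 1: in this assay compound 3 gives 7760 nM. A step of modest size toward a higher number, or none beyond the scatter, is expected. Compound 4 is therefore estimated at 12000 nM, with a range from 4000 nM to 36000 nM.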

Compound 4, concentration lethal to 50% of the cells: 8120 nM
Compound 4: middle estimate off by 1.5-fold (0.17 log units), on the high side; the measured number falls inside the stated range.
By their numbers in this assay, from the lowest: compounds 1, 3 and 4 (each within the scatter of the next); then compound 2.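

In this assay, going by these compounds alone, hydrogen in place of chloro on the aromatic carbon between two ring nitrogen atoms gives a 1.1-fold higher number from compound 1 to compound 4 (0.05 log units; within the scatter), the first single-place step. The chloro at this position can therefore be lost without a change beyond the scatter, so compound 1 and compound 4 cannot be ordered, and the reading at this carbon no longer rests on a comparison between compounds that differ in more than one place. Nothing at hand explains why this exchange leaves the number within the scatter, and no supporting evidence bears on it.

As far as these compounds go, this single exchange shows only that hydrogen and chloro cannot be told apart at this carbon, so it remains open whether a methyl or methoxy group there would also leave the number within the scatter, and compound 2 cannot settle this, as it differs from compound 1 in more than one place. Also open, from the compounds shown here alone, is whether the chloro remaining on the core of compound 4 could be exchanged for hydrogen with a similarly small step.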